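Swapping Diethylamino for Isopropyl on the Sulfonyl Sulfur

A few compounds are considered here, and "the series" means these few. Any claim that something is new, unique, unknown or untested is made for them only; others in the source may bear on it.

Compound 1 `CCN(CC)S(=O)(=O)c1ccc(S(=O)(=O)N2CCC[C@@H](C(=O)N3CCC(F)(F)CC3)C2)cc1` shows no measurable inhibition in a functional assay on MIA PaCa-2 cells (Homo sapiens) for inhibition, read by MTT assay, with a stated time of 3 days; on this read-out higher numbers stand for weaker inhibition and lower numbers for stronger inhibition: compound 1 gives > 10000 nM, which is a limit of the assay and not a number. Compound 2 `CCN(CC)S(=O)(=O)c1ccc(S(=O)(=O)N2CCC[C@@H](C(=O)N[C@H]3CC[C@H](OC)CC3)C2)cc1`, carrying (4-methoxycyclohexyl)amino in place of 4,4-difluoropiperidin-1-yl on a carbonyl carbon, likewise reaches only a limit; in this assay compound 2 gives > 10000 nM. The step that the two limits leave unreadable from compound 1 to compound 2 is therefore unreadable, both results sitting at the limit of > 10000 nM in this assay, at which 2 of the 2 values shown sit. Compound 3 `CC(C)S(=O)(=O)c1ccc(S(=O)(=O)N2CCC[C@@H](C(=O)N3CCC(F)(F)CC3)C2)cc1` differs from compound 1 at another place: isopropyl in place of diethylamino on a sulfonyl sulfur. Within the data shown here, no measured pair touches the sulfonyl sulfur, so nothing among the measurements bears on this change, and the starting point itself is only a limit. Compound 3 is expected to stay near that limit, with an estimated 10000 nM and a range from 3000 nM to 30000 nM. The expected step is then a number no higher from compound 1 to compound 3 (the limit leaves the size open), that is, no change beyond the scatter.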

Compound 3, half-maximal inhibitory concentration: > 3000 nM
Compound 3: no number, only a limit; the forecaster's own chance of this, stated with the estimate: 80%; the middle value does not contradict the limit.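

In this assay compound 3 gives > 3000 nM, which is a limit and not a number. Compound 1 also stands only at a limit, so the step between compound 1 and compound 3 cannot be read. As far as these compounds go, whether isopropyl in place of diethylamino on a sulfonyl sulfur changes inhibition at all remains open.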